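Isopropyl for Fluoro on the Aryl Ring

This account rests on a few compounds, and the source may have more. Where it says the series, first, only, none or still open, it means among the compounds named here.

Measured so far:
compound 1 `O=C(NO)c1ccc(NCc2nc(-c3ccccc3)nn2-c2cccc(Cl)c2)cc1`: 62.3%
compound 2 `O=C(NO)c1ccc(NCc2nc(-c3ccccc3)nn2-c2ccc(F)cc2)cc1`: 67.6%

In an assay on Sf9 cells for inhibition of protein deacetylase HDAC6 (Homo sapiens), read by fluorescence, with a stated time of 40 min, tested at 100 nM (on this read-out lower numbers stand for less inhibition and higher numbers for more inhibition at the one concentration tested (going by the name of the read-out)), compound 2 gives 67.6%, and compound 1 gives 62.3%, the two lying within the scatter of each other. Compound 3 `CC(C)c1ccc(-n2nc(-c3ccccc3)nc2CNc2ccc(C(=O)NO)cc2)cc1` has not been measured. It differs from compound 2 by isopropyl in place of fluoro on an aromatic carbon. Going by the values given here, the only measured step, a number 5.3 percentage points higher from compound 1 to compound 2 (within the scatter), also swapped the group on that ring and stayed within the scatter, so a step of similar small size with no clear direction is expected here, namely a number 2.6 percentage points lower from compound 2 to compound 3 (within the scatter). Compound 3 is therefore estimated at 65%, between 45% and 85%.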

Compound 3, a percentage reported as inhibition, at one concentration (the size of the read-out at that concentration, not a potency): 52.6%
For compound 3 the middle estimate is 12.4 percentage points above the measured one; low and high end bracket the measured number.
By their numbers in this assay, from the lowest: compounds 3, 1 and 2 (each within the scatter of the next, the first and the last beyond it).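

In this assay the group on this ring does make a difference: isopropyl in place of fluoro gives a number 15 percentage points lower from compound 2 to compound 3 (beyond the scatter) and so passes the scatter, which the earlier step on this ring did not. Going by these compounds alone, the change from 3-chlorophenyl to 4-isopropylphenyl gives a number 9.7 percentage points lower from compound 1 to compound 3 (within the scatter) so only the step from the fluoro compound is clear. Nothing available here says why the number falls. Still open, on these data alone, is how a methyl, a methoxy or an amine would read in the same place, and so whether the fall tracks the heavy-atom count of the group at all.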